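This account rests on a few compounds, and the source may have more. Where it says the series, first, only, none or still open, it means among the compounds named here.

Measured compounds in a functional assay on HepG2 cells (Homo sapiens) for antiproliferative activity, read by CCK-8 assay, with a stated time of 48 h; on this read-out higher numbers stand for weaker inhibition and lower numbers for stronger inhibition:
compound 1 `COc1ccc(/C=C\c2cc(OC)c(OC)c(OC)c2)cc1OCc1ccc(CN2CC(C(=O)O)C2)cc1`: > 10000 nM, a limit of this assay and not a number.
compound 2 `COc1ccc(/C=C\c2cc(OC)c(OC)c(OC)c2)cc1OCc1ccc(CN2CCCC[C@H]2C(=O)O)cc1`: > 10000 nM, again a limit of this assay and not a number.

Compound 2 therefore stands at the limit of this assay, with nothing measured for it beyond that limit. Among the measured compounds shown here, the single measured step, a step that the two limits leave unreadable from compound 1 to compound 2, cannot be sized because of the limit of > 10000 nM in this assay, at which 2 of the 2 values shown sit. Compound 3 `COc1ccc(/C=C\c2cc(OC)c(OC)c(OC)c2)cc1OCc1ccc(CN2CC[C@@H](O)C2)cc1` differs from compound 2 by 3-hydroxypyrrolidin-1-yl in place of 2-carboxypiperidin-1-yl on a saturated chain carbon bound to an aromatic carbon. For the measured compounds named here, no measured step covers an exchange of this kind, and the one step that exists gives no size and no direction, so nothing in the numbers points the step from compound 2 to compound 3 either way. The expectation for compound 3 rests only on compound 2 sitting at > 10000 nM, a limit, and on the absence of any readable change so far. Compound 3 is therefore expected to remain at or near the limit of this assay, estimated at 15000 nM with a range from 3000 nM to 60000 nM. This estimate means an expected step that the limit leaves unreadable from compound 2 to compound 3, which is expected to stay within the usual scatter.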

Compound 3, half-maximal inhibitory concentration: 6200 nM
Beside the measured number, compound 3's estimate is 2.4-fold (0.38 log units) above it; measured number inside the range.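

In this assay, among the compounds shown here, compound 3 gives 6200 nM as the first reading that is a number and not a limit, so the assay can return a value for a compound changed only at this place, on a saturated chain carbon bound to an aromatic carbon. Putting 3-hydroxypyrrolidin-1-yl in place of 2-carboxypiperidin-1-yl gives an at least 1.6-fold lower number from compound 2 to compound 3 (0.20 log units; that floor lies within the scatter) and putting it in place of 3-carboxyazetidin-1-yl gives an at least 1.6-fold lower number from compound 1 to compound 3 (0.20 log units; that floor lies within the scatter) and neither floor therefore establishes a change beyond the scatter on its own. The real size of both steps stays unread because each starts from a compound with no number, only a limit: the limit of > 10000 nM in this assay, at which 2 of the 3 values shown sit.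

The compounds shown do not separate the entry of the hydroxyl from the departure of the carboxylic acid, and they do not separate either from the change of ring size. A plain pyrrolidin-1-yl, a 3-hydroxypiperidin-1-yl or the other stereoisomer of 3-hydroxypyrrolidin-1-yl at the same place would bear on these open points.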